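A Ring Swap on the Carbonyl Carbon of Compound 1

This account rests on a few compounds, and the source may have more. Where it says the series, first, only, none or still open, it means among the compounds named here.

Compound 1 `Cc1nc(S(C)(=O)=O)ccc1Oc1ncnc(OC2CCN(C(=O)OC3(C(F)(F)F)COC3)CC2)c1F`: 342 nM
Compound 2 `CCc1cnc(C(=O)N2CCC(Oc3ncnc(Oc4ccc(S(C)(=O)=O)nc4C)c3F)CC2)nc1`: 40.8 nM

Of the compounds shown here, two have so far been measured in a functional assay on isolated protein for inhibition of Glucose-dependent insulinotropic receptor (Rattus norvegicus), read by HTRF and cAMP accumulation; on this read-out higher numbers stand for an effect only at larger amounts of compound and lower numbers for an effect already at smaller amounts. Compound 1 gives 342 nM in this assay, the highest of the two numbers, and its nearest neighbour compound 2 gives 40.8 nM. Within the data shown here, the single measured step between them, an 8.4-fold lower number from compound 1 to compound 2 (0.92 log units; beyond the scatter), came from putting 5-ethylpyrimidin-2-yl in place of (3-(trifluoromethyl)oxetan-3-yl)oxy on a carbonyl carbon.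

Compound 3 `Cc1nc(S(C)(=O)=O)ccc1Oc1ncnc(OC2CCN(C(=O)c3ncc(Cl)cn3)CC2)c1F` has not yet been measured. It differs from compound 1 in one place only: 5-chloropyrimidin-2-yl in place of (3-(trifluoromethyl)oxetan-3-yl)oxy on a carbonyl carbon. Among the measured compounds shown here, this change sits on the same carbonyl carbon as the measured step, and 5-chloropyrimidin-2-yl closely resembles 5-ethylpyrimidin-2-yl, so that step is the one comparison that bears on compound 3. A drop in this assay of roughly similar size is expected, due to an 8.4-fold lower number from compound 1 to compound 2 (0.92 log units; beyond the scatter). Compound 3 is therefore expected to give about 50 nM, within a range of 20 nM to 150 nM. That estimate for compound 3 amounts to an expected step of a 6.8-fold lower number from compound 1 to compound 3 (0.84 log units; beyond the scatter).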

Compound 3, half-maximal effective concentration: 30.9 nM
Compound 3: middle estimate off by 1.6-fold (0.21 log units), on the high side, within the range that was stated.
By their numbers in this assay, from the lowest: compounds 3 and 2 (each within the scatter of the next); then compound 1.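

In this assay, the step to a second pyrimidin-2-yl amide, an 11-fold lower number from compound 1 to compound 3 (1.04 log units; beyond the scatter), matches the direction seen with compound 2, so the drop on leaving (3-(trifluoromethyl)oxetan-3-yl)oxy on this carbonyl carbon now rests on two separate replacements rather than one. The new comparison also tests the substituent on the pyrimidine ring itself: chloro in place of ethyl on an aromatic carbon gives a 1.3-fold lower number from compound 2 to compound 3 (0.12 log units; within the scatter), so this read-out does not separate 5-chloropyrimidin-2-yl from 5-ethylpyrimidin-2-yl. No measurement is available to explain why either ring differs from the group it replaces.

Going by these compounds, it remains open whether the pyrimidine ring is needed for the lower numbers, or whether a phenyl or pyridin-2-yl ring on the same carbonyl carbon would serve as well. Also unsettled is how far the match between chloro and ethyl extends, since a methoxy, a nitrile or an amine on that aromatic carbon could give a quite different number.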